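Swapping cyclohexyl for oxan-4-yl on the sulfonyl sulfur

This account rests on a few compounds, and the source may have more. Where it says the series, first, only, none or still open, it means among the compounds named here.

In an ADME assay on microsomes from liver (Homo sapiens) for pharmacokinetics, read by LC-MS, with a stated time of 60 min, tested at 1 uM (a lower number here means slower removal, a higher number faster removal of the compound), compound 1 (`O=C(NCc1ccc(S(=O)(=O)c2ccccc2)cc1)N1Cc2ccncc2C1`) gives 7.5 mL/min/kg, compound 2 (`O=C(NCc1ccc(S(=O)(=O)c2cc(F)cc(F)c2)cc1)N1Cc2ccncc2C1`) gives 8 mL/min/kg and compound 3 (`O=C(NCc1ccc(S(=O)(=O)C2CCCCC2)cc1)N1Cc2ccncc2C1`) gives 16 mL/min/kg. The numbers set compound 3 clearly apart from only one of the other two, with a 2.1-fold higher number from compound 1 to compound 3 (0.33 log units; beyond the scatter) and a 2.0-fold higher number from compound 2 to compound 3 (0.30 log units; within the scatter), while a 1.1-fold higher number from compound 1 to compound 2 (0.03 log units; within the scatter).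

Compound 4 (`O=C(NCc1ccc(S(=O)(=O)C2CCOCC2)cc1)N1Cc2ccncc2C1`) differs from compound 3 as follows: oxan-4-yl in place of cyclohexyl on a sulfonyl sulfur. Within the data shown here, no measured step involves oxan-4-yl, so the guide is the modest size of a 2.1-fold higher number from compound 1 to compound 3 (0.33 log units; beyond the scatter). On that basis, a small downward move within the scatter is expected, namely a 1.6-fold lower number from compound 3 to compound 4 (0.20 log units; within the scatter). For compound 4 the estimated clearance is 10 mL/min/kg, with an expected range of 6 mL/min/kg to 17 mL/min/kg.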

Compound 4, clearance: 6 mL/min/kg
Estimate against measurement, compound 4: 1.7-fold (0.22 log units) above; the measured number falls inside the stated range.
By their numbers in this assay, from the lowest: compounds 4, 1, 2 and 3 (each within the scatter of the next, the first and the last beyond it).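

In this assay, oxan-4-yl in place of cyclohexyl on the sulfonyl sulfur gives a 2.7-fold lower number from compound 3 to compound 4 (0.43 log units; beyond the scatter), so a non-aromatic ring at this position does not by itself bring the faster removal seen with compound 3. Set against the aromatic groups, oxan-4-yl stays level, with a 1.3-fold lower number from compound 1 to compound 4 (0.10 log units; within the scatter) and a 1.3-fold lower number from compound 2 to compound 4 (0.12 log units; within the scatter). Nothing available explains the step from cyclohexyl to oxan-4-yl. The compounds shown leave open where a piperidine ring or an open-chain ether on the sulfonyl sulfur would fall in this assay.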